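Trifluoromethoxy in place of trifluoromethyl on compound 3

This account rests on a few compounds, and the source may have more. Where it says the series, first, only, none or still open, it means among the compounds named here.

Compound 1 `Fc1ccccc1-c1ccc2[nH]c(C3=NOC4(CCCCC4)C3)nc2c1` gives 55%
Compound 2 `FC(F)(F)Oc1ccccc1-c1ccc2[nH]c(C3=NOC4(CCCCC4)C3)nc2c1` gives 74%
Compound 3 `Fc1cccc(C(F)(F)F)c1-c1ccc2[nH]c(C3=NOC4(CCCCC4)C3)nc2c1` gives 37%

In an ADME assay on microsomes from liver (Rattus norvegicus) for metabolic stability, with a stated time of 10 min (a lower number here means that less of the compound is left, a higher number that more of the compound is left), compound 3 stands lowest of the three at 37% and is the starting point here. Compound 4 `Fc1cccc(OC(F)(F)F)c1-c1ccc2[nH]c(C3=NOC4(CCCCC4)C3)nc2c1` carries trifluoromethoxy in place of trifluoromethyl on an aromatic carbon and keeps the fluoro group. Going by the values given here, no measured step makes this exact exchange. Two bear on it: a number 19 percentage points higher from compound 1 to compound 2 (beyond the scatter) with trifluoromethoxy in place of fluoro on an aromatic carbon, and a number 18 percentage points lower from compound 1 to compound 3 (beyond the scatter) with trifluoromethyl in place of hydrogen on an aromatic carbon. Both are modest, and they run in opposite directions. A modest rise is therefore expected in this assay with an estimated step of a number 15 percentage points higher from compound 3 to compound 4 (beyond the scatter) for this exchange. Compound 4 is expected at 52% with an estimated range from 35% to 70% in this measurement.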

Compound 4, percent of the compound remaining: 44%
Compound 4: the middle estimate sits 8 percentage points above what was measured; low and high end bracket the measured number.
By their numbers in this assay, from the lowest: compounds 3 and 4 (each within the scatter of the next); then compound 1; then compound 2.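

In this assay, trifluoromethoxy in place of trifluoromethyl, ortho to a large group, makes no clear difference, with a number 7 percentage points higher from compound 3 to compound 4 (within the scatter). Trifluoromethoxy does not keep the high number of compound 2 once the fluoro group is also present, as a number 30 percentage points lower from compound 2 to compound 4 (beyond the scatter) shows, and a number 11 percentage points lower from compound 1 to compound 4 (beyond the scatter) shows that the pairing also falls short of the fluoro group alone. No measurement shown here explains these shifts.

From the compounds shown here alone, it remains open whether a nitrile or a methoxy group at this place would give a number like those of compound 3 and compound 4.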